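The compounds below may be only part of what the source reports. "The series", "measured", "known", "first", "only" and "open" are said of these compounds alone.

In a functional assay on KG-1 cells (Homo sapiens) for cytotoxicity, read by luminescence and CellTiter-Glo, with a stated time of 3 days (a higher number here means a weaker inhibitor, a lower number a stronger inhibitor), compound 3 `COc1ccc(C(=O)Nc2ccc(C#N)cc2)c(O)c1` gives 5430 nM. This lies within the scatter of compound 2 `N#Cc1ccc(NC(=O)c2ccc(-c3cccnc3)cc2O)cc1` at 7940 nM. Compound 1 `Cc1ccc(C(=O)Nc2ccc(C#N)cc2)c(O)c1` gives 2560 nM. Compound 4 `N#Cc1ccc(NC(=O)c2ccc(-c3ccccc3)cc2O)cc1` has phenyl in place of methoxy on an aromatic carbon, meta to a hydroxy group and para to a large group: phenyl in place of methoxy on an aromatic carbon. The closest evidence is the exchange of pyridin-3-yl and methoxy, a 1.5-fold lower number from compound 2 to compound 3 (0.17 log units; within the scatter). The steps from the methyl group were modest: a 3.1-fold higher number from compound 1 to compound 2 (0.49 log units; beyond the scatter) and a 2.1-fold higher number from compound 1 to compound 3 (0.33 log units; beyond the scatter). No step beyond the scatter is therefore expected in this assay. The estimated step is a 1.0-fold higher number from compound 3 to compound 4 (0.01 log units; within the scatter). For compound 4, the expected value is 5500 nM, with an estimated range of 2300 nM to 13000 nM.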

Compound 4, half-maximal inhibitory concentration: 410 nM
Compound 4: the middle estimate sits 13-fold (1.13 log units) above what was measured; the measured number lies below the stated range.
By their numbers in this assay, from the lowest: compound 4; then compound 1; then compounds 3 and 2 (each within the scatter of the next).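

In this assay, phenyl at this position gives the lowest number of the series, against each of the other groups (a 13-fold lower number from compound 3 to compound 4 (1.12 log units; beyond the scatter); a 19-fold lower number from compound 2 to compound 4 (1.29 log units; beyond the scatter); a 6.2-fold lower number from compound 1 to compound 4 (0.80 log units; beyond the scatter)). The earlier compounds shown here showed pyridin-3-yl giving a higher number than methyl, so a six-membered aromatic ring here does not alone bring the gain: the all-carbon ring of compound 4 differs sharply from the ring of compound 2. Nothing shown gives a reason for this difference. The compounds leave open how a cyclohexyl or benzyl group would compare at this position, and whether an amine on the phenyl ring would keep the gain.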